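Piperazine amide series: alkoxyphenyl in place of dichlorophenyl

A few compounds are considered here, and "the series" means these few. Any claim that something is new, unique, unknown or untested is made for them only; others in the source may bear on it.

Measured so far:
compound 1 `Cc1nc(-c2ccccc2)c(C(=O)N2CCN(c3cccc(Cl)c3Cl)CC2)o1`: 133 nM
compound 2 `COc1cc(OC)cc(N2CCN(C(=O)c3oc(C)nc3-c3ccccc3F)CC2)c1`: 10.3 nM

In a functional assay on HL-60 cells (Homo sapiens) for inhibition, read by MTT assay, with a stated time of 72 h (a lower number here means a stronger inhibitor, a higher number a weaker inhibitor), compound 1 gives 133 nM, the higher of the two numbers in hand. Compound 2 differs from compound 1 in two places at once; in this assay compound 2 gives 10.3 nM, a clearly lower number, beyond the scatter; with two changes together, no single step can be read from the pair.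

Compound 3 `CCOc1cccc(N2CCN(C(=O)c3oc(C)nc3-c3ccccc3)CC2)c1` is not yet measured. It differs from compound 1 in one place: 3-ethoxyphenyl in place of 2,3-dichlorophenyl on an amine nitrogen in a ring. The other parts of compound 1 are kept.

An expectation rests only on the pair above. Because compound 2 with an alkoxy-bearing phenyl on the ring nitrogen gives 10.3 nM, a lower number than compound 1 is expected for compound 3, though a single ethoxy group is not the same change. A step of a 2.2-fold lower number from compound 1 to compound 3 (0.35 log units; beyond the scatter) toward a lower number is expected, of modest size, and it may also fall within the scatter. Compound 3 is estimated at 60 nM, within 15 nM to 250 nM.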

Compound 3, half-maximal inhibitory concentration: 151 nM
Compound 3: middle estimate off by 2.5-fold (0.40 log units), on the low side; the range from low to high includes it.
By their numbers in this assay, from the lowest: compound 2; then compounds 1 and 3 (each within the scatter of the next).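

In this assay, 3-ethoxyphenyl in place of 2,3-dichlorophenyl on the amine nitrogen in the ring gives a 1.1-fold higher number from compound 1 to compound 3 (0.06 log units; within the scatter) and so leaves the reading at this position unchanged within the scatter. This pair shows that the two chlorine atoms can give way to a single ethoxy group with no readable step, and that one ethoxy group on this phenyl does not by itself bring a lower number. No measurement in hand bears on the reason these two groups read alike.

On these data alone, the pairs with compound 2 differ in more than one place and cannot be read as steps, so the separate parts played by its fluorine and its two methoxy groups stay open. Also open, as far as these compounds go, is how a longer alkoxy chain, an amine or a carboxylic acid on this phenyl would read in this assay.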